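This account rests on a few compounds, and the source may have more. Where it says the series, first, only, none or still open, it means among the compounds named here.

Measured compounds:
- compound 1, `CCCCNc1nccnc1C(=O)NCc1ccccc1`, in an ADME assay on MDCK cells (Canis lupus familiaris) for cytotoxicity, read by microscopy, with a stated time of 6 days; a higher number here means that more compound is tolerated, a lower number that less compound is tolerated: > 100000 nM
- compound 2, `O=C(NCc1ccccc1)c1nccnc1Cl`: "not determined" (no result reported)

Two compounds share a core carrying a benzylamide. In this assay compound 1 reaches only a limit of the assay, > 100000 nM, so no number is known for it. For compound 2 this assay reports "not determined" (no result reported), so compound 2 stands nowhere on the numbers shown; the only value shown is the limit of > 100000 nM in this assay, at which 1 of the 2 values shown sits, and that belongs to compound 1.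

Compound 3, `CCCCCCNc1nccnc1C(=O)NCc1ccccc1`, is the next compound to be measured in this assay. It differs from compound 2 by hexylamino in place of chloro on an aromatic carbon. Going by the values given here, no measured step connects compound 2 to compound 3, so the size and direction of the change in this assay cannot be taken from data; the only guide is that compound 1, with a butylamino group in the same place, sits at the limit. Compound 3 is expected to give about 80000 nM, within a range from 20000 nM to 100000 nM.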

Compound 3, minimum cytotoxic concentration: 100000 nM
Compound 3: middle estimate off by 1.3-fold (0.10 log units), on the low side, and the stated range covers the measured number.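

In this assay compound 3, with hexylamino on the aromatic carbon, gives 100000 nM, the only plain number shown so far, so this position now has a value that is not a limit. Compound 1 stands at a limit, > 100000 nM, and that is not a number. Ethyl in place of hydrogen on the chain of butylamino gives a number no higher from compound 1 to compound 3 (the limit leaves the size open), and the size of this change cannot be read because the only figure for compound 1 is a limit: the limit of > 100000 nM in this assay, at which 1 of the 3 values shown sits.

On these data alone, it remains open whether a chain longer than hexylamino, or a carboxylic acid at the end of the chain, would bring the number in this assay down. As far as these compounds go, compound 2 has no reported result, so how either amino chain compares with chloro in this place also stays unknown.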